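Swapping a Fluoro for a Methyl on a Sulfonamide Tail

The source may hold more compounds than are shown below. What is called first, only, known or untested is meant among the compounds shown, and "the series" means these compounds.

Of the compounds shown here, three sharing one core have been tested in a functional assay on CFPAC-1 cells (Homo sapiens) for antiproliferative activity, read by MTT assay, with a stated time of 72 h; a higher number here means a weaker inhibitor, a lower number a stronger inhibitor. Compound 1, `CC(C)(C)OC(=O)N1CCN(C(=S)SCc2cn(C[C@H](O)[C@H]3OC(=O)C(OCc4ccccc4)=C3OCc3ccccc3)nn2)CC1`, gives only a limit in this assay, namely > 100000 nM. Compound 2, `O=C1O/C(=C\Cn2cc(-c3cc(C(F)(F)F)cc(C(F)(F)F)c3)nn2)C(OCc2ccccc2)=C1OCc1ccccc1`, likewise gives only a limit, > 100000 nM. Among the compounds with values here, compound 3, `O=C1O[C@H]([C@@H](O)Cn2cc(CNS(=O)(=O)c3ccc(F)cc3)nn2)C(OCc2ccccc2)=C1OCc1ccccc1`, is the one member with a number: in this assay compound 3 gives 34700 nM. Among the values shown, compound 3 therefore stands alone as the only measured figure, while the other two sit at the limit of > 100000 nM in this assay, at which 2 of the 3 values shown sit.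

Compound 4, `Cc1ccc(S(=O)(=O)NCc2cn(C[C@H](O)[C@H]3OC(=O)C(OCc4ccccc4)=C3OCc3ccccc3)nn2)cc1`, has not yet been measured. It differs from compound 3 in one place: methyl in place of fluoro on an aromatic carbon. Within the data shown here, no step between two measured compounds is given here, so no measured pair shows what such an exchange does. With one heavy atom leaving and one heavy atom entering, and no change in ring count, donors, acceptors or charge, the value is expected to move little, and the step expected is a 1.1-fold higher number from compound 3 to compound 4 (0.04 log units; within the scatter), which stays within the usual scatter. Compound 4 is expected to give about 38000 nM in this assay, within a range from 13000 nM to 100000 nM.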

Compound 4, half-maximal inhibitory concentration: 68000 nM
For compound 4 the middle estimate is 1.8-fold (0.25 log units) below the measured one; measured number inside the range.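

In this assay, exchanging 4-fluorophenyl for 4-methylphenyl on the sulfonamide tail gives a 2.0-fold higher number from compound 3 to compound 4 (0.29 log units; within the scatter). Within the data shown here, this is the first measured pair that differs in one place, and it shows that at this aromatic carbon, para to a large group, fluoro and methyl cannot be told apart in this assay. Compound 1 and compound 2 each give only a limit, not a number, so neither offers a further step to set beside this one: the limit of > 100000 nM in this assay, at which 2 of the 4 values shown sit.

From the compounds shown here alone, what remains open is whether any other group on this aromatic carbon, such as an amine, a carboxylic acid or a methoxy group, would move the number beyond the scatter. A single pair also cannot show whether the same exchange would behave alike at another position on the aromatic ring, or whether a longer chain in place of the methyl would leave the value just as little changed.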